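The compounds below may be only part of what the source reports. "The series", "measured", "known", "first", "only" and "open" are said of these compounds alone.

Measured in an ADME assay on the whole organism (strain ICR) for pharmacokinetics, with Mus musculus as the target, read by HPLC, at a dose of 50 mg/kg by the oral route; on this read-out lower numbers stand for lower exposure and higher numbers for higher exposure at the dose given:
- compound 1 `O=c1nc(N2CCN(CC3CCCCC3)CC2)sc2c([N+](=O)[O-])cc(C(F)(F)F)cc12`: 2850 nM
- compound 2 `O=c1nc(N2CCC3(CCN(Cc4ccc(Br)cc4)CC3)CC2)sc2c([N+](=O)[O-])cc(C(F)(F)F)cc12`: 2820 nM

In this read-out, compound 2 at 2820 nM stands level with compound 1 at 2850 nM, as the two values lie within the usual scatter of repeated measurements. The next compound to be tested, compound 3 `O=c1nc(N2CCC3(CCN(Cc4cc(F)cc(F)c4)CC3)CC2)sc2c([N+](=O)[O-])cc(C(F)(F)F)cc12`, has 3,5-difluorophenyl in place of the 4-bromophenyl of compound 2, on a saturated chain carbon bound to an amine nitrogen in a ring (3,5-difluorophenyl in place of 4-bromophenyl on a saturated chain carbon bound to an amine nitrogen in a ring). Within the data shown here, no measured pair differs in only one place, so the data give no direct guide to the effect of this swap. With nothing to suggest a shift in either direction, the starting point is compound 2 at 2820 nM, and no change beyond the scatter is expected. The expected change is a 1.1-fold lower number from compound 2 to compound 3 (0.04 log units; within the scatter). Compound 3 is estimated at 2600 nM, with an expected range from 1100 nM to 6000 nM.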

Compound 3, maximal plasma concentration: 768 nM
For compound 3 the middle estimate is 3.4-fold (0.53 log units) above the measured one; measured number below the stated range.
By their numbers in this assay, from the lowest: compound 3; then compounds 2 and 1 (each within the scatter of the next).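

In this assay the group on the saturated chain carbon bound to an amine nitrogen in a ring proves able to change exposure: 3,5-difluorophenyl in place of 4-bromophenyl gives a 3.7-fold lower number from compound 2 to compound 3 (0.56 log units; beyond the scatter) with nothing else in the structure altered. Compound 1 and compound 2 differ in more than one place, so their level values could not show this sensitivity. Why exposure falls with this swap remains unexplained, as nothing measured here bears on the cause.

This single step cannot separate the loss of the bromine from the gain of the two fluorines or from where those atoms sit on the ring. Plain phenyl, 4-fluorophenyl and 3,5-dibromophenyl at this place would help to pull those changes apart, and the compounds shown leave their exposure open.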